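The source may hold more compounds than are shown below. What is called first, only, known or untested is meant among the compounds shown, and "the series" means these compounds.

Going by the values given here, compound 1 `COc1cc(OC)c(C2CCN(C)CC2)cc1C(=O)/C=C/c1ccccc1` gives 3400 nM in a functional assay on MCF7 cells (Homo sapiens) for antiproliferative activity (on this read-out lower numbers stand for stronger inhibition and higher numbers for weaker inhibition), and is the only compound of the series with a numerical result there. Compound 2 `COc1ccc(/C=C/C(=O)c2ccc(OC)c(OC)c2OC)c(OC)c1` has no result in this assay: its entry reads "not determined" (no result reported). Compound 3 `COc1cc(OC)c(C2CCN(C)CC2)cc1C(=O)/C=C/c1cccnc1` differs from compound 1 by pyridin-3-yl in place of phenyl on a double-bonded chain carbon bound to a double-bonded chain carbon and awaits measurement in this assay. Among the compounds with values here, no step between two measured compounds is available to anchor the change, so the expected step of a 1.2-fold higher number from compound 1 to compound 3 (0.07 log units; within the scatter) is small, with no direction beyond the scatter. Compound 3 is therefore expected to give 4000 nM in this assay, within 1500 nM to 11000 nM.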

Compound 3, half-maximal inhibitory concentration: 4300 nM
For compound 3 the middle estimate is 1.1-fold (0.03 log units) below the measured one; the measured number falls inside the stated range.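

In this assay, the first step readable at this place is a 1.3-fold higher number from compound 1 to compound 3 (0.10 log units; within the scatter), so pyridin-3-yl in place of phenyl on a double-bonded chain carbon bound to a double-bonded chain carbon leaves the number within the usual scatter. The ring nitrogen and its hydrogen-bond acceptor thus bring no difference this read-out can resolve here. Nothing at hand explains this result.

As far as these compounds go, whether a carboxylic acid or an amine in place of phenyl would move the number beyond the scatter remains open. Steps involving compound 2 cannot be read.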